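A few compounds are considered here, and "the series" means these few. Any claim that something is new, unique, unknown or untested is made for them only; others in the source may bear on it.

Values so far in a functional assay on HepG2 cells (Homo sapiens) for antiproliferative activity, read by MTT assay, with a stated time of 48 h (a higher number here means a weaker inhibitor, a lower number a stronger inhibitor), follow.

- compound 1 `COc1ccc(/C=C/c2cc(OC)cc(OC)c2/C=C/C(=O)c2ccc(Cl)c(Cl)c2)cc1` gives 10.8 ug/mL
- compound 2 `COc1ccc(/C=C/c2cc(OC)cc(OC)c2/C=C/C(=O)c2cccc(OC)c2)cc1` gives 11.6 ug/mL
- compound 3 `COc1ccc(/C=C/c2cc(OC)cc(OC)c2/C=C/C(=O)c2ccccc2C)cc1` gives 5.3 ug/mL

In this assay compound 3 gives 5.3 ug/mL as the lowest of the three numbers, beyond the scatter from both others. For the measured compounds named here, compound 4 `COc1ccc(/C=C/c2cc(OC)cc(OC)c2/C=C/C(=O)c2ccc(C)cc2C)cc1` departs from compound 3 by methyl in place of hydrogen on an aromatic carbon as its only change: methyl in place of hydrogen on an aromatic carbon, meta to a methyl group and para to a large group, so that 2-methylphenyl becomes 2,4-dimethylphenyl. Going by the values given here, no measured step makes this exact change. The nearest evidence is the exchange of the whole substituted phenyl group on the carbonyl carbon. There, a 2.0-fold lower number from compound 1 to compound 3 (0.31 log units; beyond the scatter) and a 2.2-fold lower number from compound 2 to compound 3 (0.34 log units; beyond the scatter) are both modest, while a 1.1-fold higher number from compound 1 to compound 2 (0.03 log units; within the scatter) stays within the scatter. With whole-group exchanges moving the number only this far, and with compound 3 as the starting point at 5.3 ug/mL, no shift beyond the scatter is expected in this assay and no firm direction can be assigned. The estimate is a 1.1-fold higher number from compound 3 to compound 4 (0.05 log units; within the scatter), which is expected to lie within the scatter. Compound 4 is expected at 6 ug/mL, with 3.2 ug/mL to 11.5 ug/mL as the estimated range.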

Compound 4, half-maximal inhibitory concentration: 0.9 ug/mL
Compound 4: middle estimate off by 6.7-fold (0.82 log units), on the high side; the measured number lies below the stated range.
By their numbers in this assay, from the lowest: compound 4; then compound 3; then compounds 1 and 2 (each within the scatter of the next).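

In this assay, for the compounds shown here, the position on the aromatic carbon meta to a methyl group and para to a large group proves highly responsive: the addition of one methyl in place of hydrogen gives a 5.9-fold lower number from compound 3 to compound 4 (0.77 log units; beyond the scatter) and so moves the number further than any exchange of the whole aryl group among the earlier compounds. Counted as exchanges of the whole group on the carbonyl carbon, 2,4-dimethylphenyl gives a 13-fold lower number from compound 2 to compound 4 (1.11 log units; beyond the scatter) and a 12-fold lower number from compound 1 to compound 4 (1.08 log units; beyond the scatter) as the only large steps in the set, which places compound 4 lowest, beyond the scatter from all three others. Nothing available accounts for why so small a change has an effect of this size.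

Going by these compounds alone, it remains open whether the shift depends on the methyl group already present in compound 3, since no compound here carries the new methyl without it. Also open, on these data alone, is whether this position would tolerate or reward an ethyl group, an amine or a carboxylic acid in place of methyl, and whether the effect extends beyond this one cell line.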